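The source may hold more compounds than are shown below. What is called first, only, known or untested is meant among the compounds shown, and "the series" means these compounds.

Measured so far in a functional assay on KB cells (Homo sapiens), read by MTT assay; a higher number here means a weaker inhibitor, a lower number a stronger inhibitor:
compound 1, `C#CC[C@]1(O)[C@@H](CO)OC(n2ccc(N)nc2=O)[C@@H]1O`, gives > 350000 nM, which is a limit of the assay and not a number.
compound 2, `C=C[C@@]1(O)[C@@H](CO)O[C@@H](n2ccc(N)nc2=O)[C@@H]1O`, gives 74300 nM.
compound 3, `CC[C@@]1(O)[C@@H](CO)O[C@@H](n2ccc(N)nc2=O)[C@@H]1O`, gives 258000 nM.

Within the data shown here, compound 3 stands highest of the two numbers that exist; its nearest neighbour is compound 2, and the one measured step, a 3.5-fold higher number from compound 2 to compound 3 (0.54 log units; beyond the scatter), is modest though beyond the scatter. For compound 1 there is only (the limit of > 350000 nM in this assay, at which 1 of the 3 values shown sits).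

Compound 4 is `C#CC[C@@]1(O)[C@@H](CO)O[C@@H](n2ccc(N)nc2=O)[C@@H]1O`. It differs from compound 3 by ethynyl in place of methyl on a saturated chain carbon bound to a saturated ring carbon. Among the measured compounds shown here, the only step that bears on it is a 3.5-fold higher number from compound 2 to compound 3 (0.54 log units; beyond the scatter), where the loss of unsaturation on the same chain raised the number. The change to compound 4 restores an unsaturated bond one carbon further out, so a movement in the opposite direction, of modest size and not larger than the measured step, is expected in this assay. Compound 4 is therefore estimated at 120000 nM, within 40000 nM to 350000 nM. This estimate means a step of a 2.2-fold lower number from compound 3 to compound 4 (0.33 log units; beyond the scatter), expected to sit near the edge of the scatter.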

Compound 4, half-maximal inhibitory concentration: > 350000 nM
Compound 4 was reported as a limit; the forecaster's own chance of this, stated with the estimate: 20%; middle value at least 2.9-fold (0.46 log units) from the limit.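

In this assay compound 4 gives > 350000 nM, which is a limit of the assay and not a number. Unsaturation on this chain does not by itself keep the number low: the data show an at least 4.7-fold higher number from compound 2 to compound 4 (0.67 log units; beyond the scatter), and compound 4 goes against reading the earlier vinyl-to-ethyl step as a general gain from an unsaturated bond. Ethynyl in place of methyl gives an at least 1.3-fold higher number from compound 3 to compound 4 (0.13 log units; that floor lies within the scatter), so no order can be stated for that pair, and the step from compound 1 to compound 4 cannot be read, with both reported as limits: the limit of > 350000 nM in this assay, at which 2 of the 4 values shown sit.

As far as these compounds go, how an amine or a longer saturated chain such as propyl at this place would read in this assay remains open. Whether configuration matters also remains open for the pair at the limit: the fact that one of compounds 1 and 4 is drawn with a defined configuration and the other without, at the place where they differ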